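Removing a Methyl from an Aromatic Nitrogen: Expected Tolerance

The source may report more compounds than this note shows. Statements on the series, on what has been measured and on what is new or still open speak of the compounds shown alone.

Compound 1 `Cn1c(-c2ccc(NC(=O)CN3CCCC3)cc2)nc2cc(C(F)(F)F)ccc21` was tested in an ADME assay on BHK cells (Mesocricetus auratus) for cytotoxicity, read by MTT assay, with a stated time of 96 h (a higher number here means that more compound is tolerated, a lower number that less compound is tolerated), where compound 1 gives 27000 nM. Compound 2 `O=C(CN1CCCC1)Nc1ccc(-c2nc3cc(C(F)(F)F)ccc3[nH]2)cc1` differs from compound 1 by hydrogen in place of methyl on an aromatic nitrogen and in this assay compound 2 gives 29000 nM, a step of a 1.1-fold higher number from compound 1 to compound 2 (0.03 log units; within the scatter).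

Compound 3 `Cn1c(-c2ccc(NC(=O)CN3CCCCC3)cc2)nc2cc(C(F)(F)F)ccc21` has a different core from compound 1, the two cores differing by piperidin-1-yl in place of pyrrolidin-1-yl on a saturated chain carbon bound to a carbonyl carbon. For compound 3 this assay reports only a limit, > 100000 nM. The resulting step is an at least 3.7-fold higher number from compound 1 to compound 3 (0.56 log units; beyond the scatter), and this rests on (the limit of > 100000 nM in this assay, at which 1 of the 3 values shown sits).

Compound 4 `O=C(CN1CCCCC1)Nc1ccc(-c2nc3cc(C(F)(F)F)ccc3[nH]2)cc1` has not been measured in this assay. It differs from compound 3 by hydrogen in place of methyl on an aromatic nitrogen, the same change that was made from compound 1 to compound 2. Because that earlier step was a 1.1-fold higher number from compound 1 to compound 2 (0.03 log units; within the scatter), compound 4 is expected to sit close to compound 3, with an estimated step that the limit leaves unreadable from compound 3 to compound 4. Since compound 3 itself reached only a limit, compound 4 is expected to give 120000 nM in this assay, most likely again reported as a limit, within a range from 55000 nM to 300000 nM.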

Compound 4, half-maximal cytotoxic concentration: 12000 nM
Beside the measured number, compound 4's estimate is 10-fold (1.00 log units) above it; the measured number lies below the stated range.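

Replacing methyl with hydrogen on the aromatic nitrogen did not carry over from one core to the other in this assay, where the new result is an at least 8.3-fold lower number from compound 3 to compound 4 (0.92 log units; beyond the scatter), and the two steps differ: the same change on two cores in this assay, a 1.1-fold higher number (0.03 log units; within the scatter) from compound 1 to compound 2 and an at least 8.3-fold lower number (0.92 log units; beyond the scatter) from compound 3 to compound 4, at least 8.9-fold (0.95 log units) apart, beyond the scatter of two such steps The change from pyrrolidin-1-yl to piperidin-1-yl also depends on the core, with the new step reading a 2.4-fold lower number from compound 2 to compound 4 (0.38 log units; beyond the scatter), and these two steps likewise part: the same change on two cores in this assay, an at least 3.7-fold higher number (0.56 log units; beyond the scatter) from compound 1 to compound 3 and a 2.4-fold lower number (0.38 log units; beyond the scatter) from compound 2 to compound 4, at least 8.9-fold (0.95 log units) apart, beyond the scatter of two such steps Compound 3 stands only at a limit, so the true size of these gaps remains unknown, and the data do not show what causes them: the limit of > 100000 nM in this assay, at which 1 of the 4 values shown sits.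

The compounds shown leave open whether the methyl-to-hydrogen change would behave more like the pyrrolidin-1-yl pair or the piperidin-1-yl pair if a morpholine or a dimethylamine stood at that end of the chain. They also leave open whether an ethyl on the aromatic nitrogen would follow the compounds that carry methyl there.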